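A few compounds are considered here, and "the series" means these few. Any claim that something is new, unique, unknown or untested is made for them only; others in the source may bear on it.

Compound 1 `O=C(Nc1ccc(F)c(-c2nc3ncc(-c4cccc(F)c4)cc3[nH]2)c1)N1CCCC1` gives 15000 ng.h/mL in an ADME assay on the whole organism (Mus musculus, strain Swiss Webster) for pharmacokinetics, read by LC-MS, at a dose of 50 mg/kg by the oral route; on this read-out higher numbers stand for higher exposure at the dose given and lower numbers for lower exposure; compound 2 `O=C(Nc1ccc(F)c(-c2nc3ncc(-c4cncc(F)c4)cc3[nH]2)c1)N1CCCC1` gives 1560 ng.h/mL; compound 3 `O=C(Nc1ccc(F)c(-c2nc3ncc(-c4ccc(F)cc4F)cc3[nH]2)c1)N1CCCC1` gives 15600 ng.h/mL.

Among these three, compound 1 stands second highest, with compound 3 nearest (a 1.0-fold higher number from compound 1 to compound 3 (0.02 log units; within the scatter)) and compound 2 furthest (a 9.6-fold lower number from compound 1 to compound 2 (0.98 log units; beyond the scatter)). Compound 4 `O=C(Nc1ccc(F)c(-c2nc3ncc(C(F)(F)F)cc3[nH]2)c1)N1CCCC1` differs from compound 1 by trifluoromethyl in place of 3-fluorophenyl on an aromatic carbon. For the measured compounds named here, no measured step matches this change: the two known steps swap one aromatic ring for another, one within the scatter and one a modest drop, while here the ring is removed altogether. Without a direct precedent, a step of no more than the scatter is expected, a 1.3-fold lower number from compound 1 to compound 4 (0.10 log units; within the scatter), and compound 4 is estimated to give 12000 ng.h/mL, likely between 4000 ng.h/mL and 35000 ng.h/mL.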

Compound 4, area under the concentration-time curve: 489 ng.h/mL
Compound 4: middle estimate off by 25-fold (1.39 log units), on the high side; the measured number lies below the stated range.
By their numbers in this assay, from the lowest: compound 4; then compound 2; then compounds 1 and 3 (each within the scatter of the next).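

Trifluoromethyl gives the lowest exposure of the four compounds in this assay, with a large drop against 3-fluorophenyl (a 31-fold lower number from compound 1 to compound 4 (1.49 log units; beyond the scatter)) and against 2,4-difluorophenyl (a 32-fold lower number from compound 3 to compound 4 (1.50 log units; beyond the scatter)). The drop is smaller but still beyond the scatter against 5-fluoropyridin-3-yl (a 3.2-fold lower number from compound 2 to compound 4 (0.50 log units; beyond the scatter)), so all three compounds with an aromatic ring at this position stand above the compound without one. Nothing shown explains this loss of exposure.

Going by these compounds, it remains open whether a saturated ring such as piperidine would give numbers like those of the aromatic compounds or like that of compound 4. The same question stands for a small amine at this position.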